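This account rests on a few compounds, and the source may have more. Where it says the series, first, only, none or still open, it means among the compounds named here.

Working notes on the series, read in a functional assay on CNE-2 cells (Homo sapiens) for antiproliferative activity, read by sulforhodamine B assay, with a stated time of 48 h; a higher number here means a weaker inhibitor, a lower number a stronger inhibitor. Compound 1 `COc1cccc(/C=C/C(=O)C(=Cc2ccc(F)cc2)C(=O)/C=C/c2cccc(OC)c2OC)c1OC` gives 610 nM, compound 2 `COc1cccc(C=C(C(=O)/C=C/c2cccc(OC)c2OC)C(=O)/C=C/c2cccc(OC)c2OC)c1OC` gives 400 nM, and compound 3 `COc1cccc(/C=C/C(=O)C(=Cc2ccc(OC)c(OC)c2OC)C(=O)/C=C/c2cccc(OC)c2OC)c1OC` gives 410 nM. Compound 3 therefore has no separate standing: its value lies within the scatter of the other two.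

The next structure is compound 4 `COc1ccc(C=C(C(=O)/C=C/c2cccc(OC)c2OC)C(=O)/C=C/c2cccc(OC)c2OC)cc1O`, and the change is 3-hydroxy-4-methoxyphenyl in place of 2,3,4-trimethoxyphenyl on a double-bonded chain carbon bound to a double-bonded chain carbon. In words, this places 3-hydroxy-4-methoxyphenyl in place of 2,3,4-trimethoxyphenyl on a double-bonded chain carbon bound to a double-bonded chain carbon.

The measured steps at this same place are small. Replacing 4-fluorophenyl gives a 1.5-fold lower number from compound 1 to compound 2 (0.18 log units; within the scatter) and a 1.5-fold lower number from compound 1 to compound 3 (0.17 log units; within the scatter), while adding a methoxy gives a 1.0-fold higher number from compound 2 to compound 3 (0.01 log units; within the scatter). No change of this group has yet left the scatter. Among the measured compounds shown here, no measured compound carries a hydroxy group, so the new feature is untested and the uncertainty stays wide on both sides.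

No shift beyond the scatter is expected in this assay. The expected change is a 1.1-fold lower number from compound 3 to compound 4 (0.03 log units; within the scatter). For compound 4 the estimated value is 380 nM, with an expected range from 150 nM to 950 nM.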

Compound 4, half-maximal inhibitory concentration: 220 nM
Compound 4: middle estimate off by 1.7-fold (0.24 log units), on the high side; the measured number falls inside the stated range.
By their numbers in this assay, from the lowest: compounds 4, 2, 3 and 1 (each within the scatter of the next, the first and the last beyond it).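

In this assay, among the compounds shown here, 3-hydroxy-4-methoxyphenyl on a double-bonded chain carbon bound to a double-bonded chain carbon gives the first step at this place to leave the scatter, though only modestly: a 2.8-fold lower number from compound 1 to compound 4 (0.44 log units; beyond the scatter). Against the two groups carrying only methoxy substituents, the same group stays within the scatter, at a 1.9-fold lower number from compound 3 to compound 4 (0.27 log units; within the scatter) and a 1.8-fold lower number from compound 2 to compound 4 (0.26 log units; within the scatter), so a hydroxy group is accepted here without a loss that can be read, and the only separation shown is from 4-fluorophenyl. No available data bear on the reason for this result.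

The share of the hydroxy group itself remains unresolved, since 3-hydroxy-4-methoxyphenyl differs from both 2,3-dimethoxyphenyl and 2,3,4-trimethoxyphenyl in more than one substituent, and a phenyl ring carrying a single hydroxy or a single methoxy would be needed to separate those contributions. The compounds shown also leave open how an amine or a carboxylic acid on this ring would read, and whether the two 2,3-dimethoxyphenyl groups on the other chains, which are common to all four compounds, can be changed at all.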